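Replacing the lactam alkene on the chain carbon with a cyclic sulfonamide

The source may hold more compounds than are shown below. What is called first, only, known or untested is meant among the compounds shown, and "the series" means these compounds.

Going by the values given here, compound 3 `CC(C)C(/C=C1/CCNC1=O)c1ccc(-c2ccc3cccc(F)c3c2)[nH]c1=O` gives 0.987 h in an ADME assay on microsomes from liver (Homo sapiens) for metabolic stability (a higher number here means that the compound lasts longer, a lower number that the compound disappears faster), and stands highest of the three numbers so far. Compound 2 `CC(C)C(/C=C1\CCNC1=O)c1ccc(-c2ccc3cccc(F)c3c2)[nH]c1=O` gives 0.713 h; the step of a 1.4-fold higher number from compound 2 to compound 3 (0.14 log units; within the scatter) is within the scatter, and the only difference between the two is the fact that one of compounds 2 and 3 is drawn with a defined configuration and the other without, at the place where they differ. Compound 1 `CC(C)C(Cc1ncc[nH]1)c1ccc(-c2ccc3cccc(F)c3c2)[nH]c1=O` gives 0.106 h, and the steps of a 6.7-fold higher number from compound 1 to compound 2 (0.83 log units; beyond the scatter) and a 9.3-fold higher number from compound 1 to compound 3 (0.97 log units; beyond the scatter) are the only ones beyond the scatter.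

Compound 4 `CC(C)C(c1ccc(-c2ccc3cccc(F)c3c2)[nH]c1=O)N1CCCCS1(=O)=O` differs from compound 3 by a group of 8 heavy atoms (4 carbon, 1 nitrogen, 2 oxygen, 1 sulfur; one six-membered non-aromatic ring with 2 hetero atoms) in place of a group of 7 heavy atoms (5 carbon, 1 nitrogen, 1 oxygen; one five-membered non-aromatic ring with 1 hetero atom), on a saturated chain carbon bound to an aromatic carbon and a saturated chain carbon. Among the compounds with values here, both measured steps beyond the scatter concern an exchange of the group on this same saturated chain carbon, and each raised the half-life modestly; no measured step brings in the entering group itself, so its effect cannot be read from the series. The expectation for compound 4 is therefore a step of a 1.4-fold lower number from compound 3 to compound 4 (0.15 log units; within the scatter) of no clear direction, likely within the scatter, with the range kept wide. Compound 4 is estimated at 0.7 h, between 0.25 h and 2 h.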

Compound 4, half-life: 0.373 h
The estimate for compound 4 lay 1.9-fold (0.27 log units) above the measured number; measured number inside the range.
By their numbers in this assay, from the lowest: compound 1; then compounds 4, 2 and 3 (each within the scatter of the next, the first and the last beyond it).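

On the saturated chain carbon, the six-membered ring with 2 hetero atoms is the first exchange shown that lowers the half-life: a 2.6-fold lower number from compound 3 to compound 4 (0.42 log units; beyond the scatter). Its standing depends on the compound it is compared with: the step of a 1.9-fold lower number from compound 2 to compound 4 (0.28 log units; within the scatter) stays within the scatter. This holds even though compounds 2 and 3 differ only in the drawn double-bond configuration. The exchange for the five-membered aromatic ring with 2 hetero atoms still gains, with a 3.5-fold higher number from compound 1 to compound 4 (0.55 log units; beyond the scatter), so the group on this carbon moves the number in both directions and compound 1 remains the shortest-lived of the four.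

The compounds shown leave open whether a five-membered cyclic sulfonamide or an open-chain sulfonamide on this carbon would track compound 4 or compound 3 in this assay. Nothing available accounts for these steps.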